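This account rests on a few compounds, and the source may have more. Where it says the series, first, only, none or still open, it means among the compounds named here.

Measured compounds in the series:
- compound 1, `NNC(=O)c1c(NC(=O)NS(=O)(=O)c2ccccc2)sc2c1CCCCC2`: 4500 nM
- compound 2, `CN1CCN(C(=O)c2c(NC(=O)NS(=O)(=O)c3ccccc3)sc3c2CCCCC3)CC1`: 49200 nM
- compound 3, `O=C(Nc1sc2c(c1C(=O)NNc1ccc(Cl)cc1)CCCCC2)NS(=O)(=O)c1ccccc1`: 5900 nM

All three numbers come from a functional assay on cells (Cancer cell lines, Homo sapiens) for inhibition, with a stated time of 48 h; on this read-out higher numbers stand for weaker inhibition of growth and lower numbers for stronger inhibition of growth. Compound 2 gives the highest of the three numbers in this assay; the nearest is compound 3, and the step of an 8.3-fold lower number from compound 2 to compound 3 (0.92 log units; beyond the scatter) lies beyond the scatter, as does the step of an 11-fold higher number from compound 1 to compound 2 (1.04 log units; beyond the scatter) in the other direction. Compound 1 and compound 3 sit within the scatter of each other, a 1.3-fold higher number from compound 1 to compound 3 (0.12 log units; within the scatter).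

Compound 4, `CCCNC(=O)c1c(NC(=O)NS(=O)(=O)c2ccccc2)sc2c1CCCCC2`, differs from compound 2 in one place: propylamino in place of 4-methylpiperazin-1-yl on a carbonyl carbon.

Among the compounds with values here, two measured steps bear on this change, both of which replace the 4-methylpiperazin-1-yl on the carbonyl carbon with a group carrying a hydrogen-bond donor: an 11-fold higher number from compound 1 to compound 2 (1.04 log units; beyond the scatter) read backwards, and an 8.3-fold lower number from compound 2 to compound 3 (0.92 log units; beyond the scatter). Both are large and in the same direction, towards lower numbers. Compound 4 also brings a hydrogen-bond donor to the carbonyl carbon, so a drop of similar size is expected, beyond the scatter. The expected step is an 8.2-fold lower number from compound 2 to compound 4 (0.91 log units; beyond the scatter).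

The estimate for compound 4 in this assay is 6000 nM, with a range from 2000 nM to 20000 nM.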

Compound 4, concentration for 50% growth inhibition: 70300 nM
Compound 4: middle estimate off by 12-fold (1.07 log units), on the low side, and the stated range ends below it.
By their numbers in this assay, from the lowest: compounds 1 and 3 (each within the scatter of the next); then compounds 2 and 4 (each within the scatter of the next).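

In this assay, a hydrogen-bond donor on the carbonyl carbon's substituent is not enough for the lower numbers: propylamino carries one, yet replacing 4-methylpiperazin-1-yl with it gives a 1.4-fold higher number from compound 2 to compound 4 (0.15 log units; within the scatter). The split instead appears among the groups that carry this donor, on the amide-type nitrogen: propyl in place of amino gives a 16-fold higher number from compound 1 to compound 4 (1.19 log units; beyond the scatter), and propyl in place of (4-chlorophenyl)amino gives a 12-fold higher number from compound 3 to compound 4 (1.08 log units; beyond the scatter). Across these four compounds, the lower numbers go with a second nitrogen attached to the amide-type nitrogen, whether it bears hydrogen or 4-chlorophenyl, and none of the four goes against this.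

Open, from the compounds shown here alone, is whether that attached nitrogen is itself what matters, which a hydroxyl or methoxy group on the amide-type nitrogen, or a benzyl group that puts an aromatic ring on carbon there, would help to separate. Nothing available here accounts for the gap between propyl and the two nitrogen-bearing groups.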